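Phenyl in Place of Hydrogen on the Pyridine of Compound 1

The source may report more compounds than this note shows. Statements on the series, on what has been measured and on what is new or still open speak of the compounds shown alone.

Compound 1 `c1ccc(-c2ccc(Cc3cccnc3)cn2)cc1`: 322 nM; compound 2 `Cc1ccncc1Cc1ccc(-c2ccccc2)nc1`: 19 nM.

In an in vitro assay on V79MZh cells for inhibition of cytochrome P450 11B2, mitochondrial (Homo sapiens) (on this read-out lower numbers stand for stronger inhibition and higher numbers for weaker inhibition), compound 1 stands highest of the two numbers shown; its nearest neighbour is compound 2, and the step of a 17-fold lower number from compound 1 to compound 2 (1.23 log units; beyond the scatter) was large. Compound 3 `c1ccc(-c2cncc(Cc3ccc(-c4ccccc4)nc3)c2)cc1` differs from compound 1 by phenyl in place of hydrogen on an aromatic carbon. Within the data shown here, the only measured step that bears on it is the methyl step from compound 1 to compound 2; phenyl is a different group, so the expectation is held loosely. For compound 3 a moderate gain, a 3.2-fold lower number from compound 1 to compound 3 (0.51 log units; beyond the scatter), is expected, giving an estimate of 100 nM with a range from 25 nM to 400 nM.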

Compound 3, half-maximal inhibitory concentration: 0.5 nM
Compound 3: the middle estimate sits 200-fold (2.30 log units) above what was measured; measured number below the stated range.
By their numbers in this assay, from the lowest: compound 3; then compound 2; then compound 1.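

In this assay the step of a 640-fold lower number from compound 1 to compound 3 (2.81 log units; beyond the scatter) shows that this aromatic carbon, two atoms from the ring nitrogen and meta to a large group, takes a whole phenyl ring with a large drop in the number. The earlier compounds shown here showed only what a methyl does, so they gave no view of a group of this size. No measurement shown here accounts for this step. Going by these compounds, whether an amine or a methoxy group at this carbon would give a similar number stays open, as does the effect of combining this phenyl with the methyl of compound 2.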